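An Ethoxy Variant of Compound 2 Before Measurement

The source may report more compounds than this note shows. Statements on the series, on what has been measured and on what is new or still open speak of the compounds shown alone.

Of the compounds shown here, three sharing one core have been tested in a functional assay on A549 cells (Homo sapiens) for antiproliferative activity, read by MTT assay, with a stated time of 48 h; a higher number here means a weaker inhibitor, a lower number a stronger inhibitor. Compound 1 `COc1ccc(/C=C/c2cc(OC)cc(OC)c2/C=C/C(=O)c2ccc(Cl)c(Cl)c2)cc1` gives 5.9 ug/mL, compound 2 `COc1ccc(/C=C/c2cc(OC)cc(OC)c2/C=C/C(=O)c2cccc(OC)c2)cc1` gives 6.1 ug/mL, and compound 3 `CCCC(C)Oc1ccc(C(=O)/C=C/c2c(/C=C/c3ccc(OC)cc3)cc(OC)cc2OC)cc1` gives 9.4 ug/mL. Compound 2 thus holds the second highest of the three numbers, yet its gaps to its neighbours are small: a 1.0-fold higher number from compound 1 to compound 2 (0.01 log units; within the scatter) and a 1.5-fold higher number from compound 2 to compound 3 (0.19 log units; within the scatter) both stay within the scatter, as does a 1.6-fold higher number from compound 1 to compound 3 (0.20 log units; within the scatter).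

Compound 4 `CCOc1ccc(C(=O)/C=C/c2c(/C=C/c3ccc(OC)cc3)cc(OC)cc2OC)cc1` has not yet been measured. It differs from compound 2 in one place: 4-ethoxyphenyl in place of 3-methoxyphenyl on a carbonyl carbon.

Going by the values given here, two measured steps bear on this change. Replacing the group on the carbonyl carbon with a different aryl ring, as from compound 1 to compound 2 or from compound 2 to compound 3, moved the number by no more than the scatter in either case. The step to compound 4 is again an exchange of the aryl ring on the carbonyl carbon, with an alkoxy substituent closest in kind to that of compound 3, so no shift beyond the scatter is expected in this assay.

Compound 4 is therefore estimated at 7 ug/mL, with a likely range from 4 ug/mL to 12.5 ug/mL, which means an expected step of a 1.1-fold higher number from compound 2 to compound 4 (0.06 log units; within the scatter).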

Compound 4, half-maximal inhibitory concentration: 7.5 ug/mL
Estimate against measurement, compound 4: 1.1-fold (0.03 log units) below; the measured number falls inside the stated range.
By their numbers in this assay, from the lowest: compounds 1, 2, 4 and 3 (each within the scatter of the next).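

In this assay, the exchange of 3-methoxyphenyl for 4-ethoxyphenyl on the carbonyl carbon gives a 1.2-fold higher number from compound 2 to compound 4 (0.09 log units; within the scatter), so a change in both the alkoxy chain and its printed ring position still leaves the number within the scatter. The new compound also isolates the alkoxy chain itself: hydrogen in place of propyl on the saturated chain carbon, which turns 4-(1-methylbutoxy)phenyl into 4-ethoxyphenyl, gives a 1.3-fold lower number from compound 3 to compound 4 (0.10 log units; within the scatter), also within the scatter, so trimming this chain has no measurable effect here. The comparison with the chlorinated ring, a 1.3-fold higher number from compound 1 to compound 4 (0.10 log units; within the scatter), stays within the scatter too, which means all four aryl groups on this carbonyl carbon now give numbers that cannot be told apart in this assay.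

Whether any group at this place can move the number beyond the scatter remains open, since a phenyl ring carrying an amine or a carboxylic acid, or a non-aryl group such as a plain methyl, is not among the compounds shown. Nothing at hand accounts for how close these four numbers lie.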